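Benzothiophen-2-yl for trifluoromethylphenyl on the chain carbon

The compounds below may be only part of what the source reports. "The series", "measured", "known", "first", "only" and "open" are said of these compounds alone.

In an assay on HEK293 cells for antagonist activity at transient receptor potential M8 protein (Canis lupus familiaris), read by fluorescence and calcium flux, with a stated time of 5 min (a higher number here means a weaker inhibitor, a lower number a stronger inhibitor), compound 2 `O=C(O)c1cccc(C2CCCN2C(=O)C(Nc2ccccc2F)c2ccc(C(F)(F)F)cc2)c1` gives 40 nM, a number that sits with those of compound 1 `O=C(C(Nc1ccccc1F)c1ccc(C(F)(F)F)cc1)N1CCCC1c1ccc(F)cc1`, which gives 37 nM, and compound 3 `O=C(O)c1ccc(C2CCCN2C(=O)C(Nc2ccccc2F)c2ccc(C(F)(F)F)cc2)cc1`, which gives 66 nM; all three lie within the scatter of one another. The measured steps of a 1.1-fold higher number from compound 1 to compound 2 (0.03 log units; within the scatter), a 1.8-fold higher number from compound 1 to compound 3 (0.25 log units; within the scatter) and a 1.7-fold higher number from compound 2 to compound 3 (0.22 log units; within the scatter) all vary the aryl on the saturated ring carbon and none changes the chain carbon. Compound 4 `O=C(O)c1cccc(C2CCCN2C(=O)C(Nc2ccccc2F)c2cc3ccccc3s2)c1` is changed there: 1-benzothiophen-2-yl in place of 4-(trifluoromethyl)phenyl on a saturated chain carbon bound to a carbonyl carbon and a nitrogen on an aromatic ring. Among the compounds with values here, no measured step bears on this position, so the series gives no direct guide; the expected step is a 1.5-fold higher number from compound 2 to compound 4 (0.18 log units; within the scatter), none beyond the scatter, with wide uncertainty. Compound 4 is expected at 60 nM, between 15 nM and 250 nM.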

Compound 4, half-maximal inhibitory concentration: 78 nM
For compound 4 the middle estimate is 1.3-fold (0.11 log units) below the measured one, and the stated range covers the measured number.
By their numbers in this assay, from the lowest: compounds 1, 2, 3 and 4 (each within the scatter of the next, the first and the last beyond it).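

Within the data shown here, the chain carbon, which no earlier step touched, now has a reading of its own: in this assay, 1-benzothiophen-2-yl in place of 4-(trifluoromethyl)phenyl gives a 2.0-fold higher number from compound 2 to compound 4 (0.29 log units; within the scatter). With 3-carboxyphenyl on the saturated ring carbon, this position therefore tolerates a change from a single aromatic ring to a fused pair without a step beyond the scatter. No evidence is available to account for this step.

Still open, on these data alone, is how a pyridine ring or a longer alkyl chain would read on this chain carbon. Also open, as far as these compounds go, is whether the same change reads alike with 4-fluorophenyl on the saturated ring carbon.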